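A few compounds are considered here, and "the series" means these few. Any claim that something is new, unique, unknown or untested is made for them only; others in the source may bear on it.

Compound 1 `COc1ccc(C2NC(=O)NC(C)=C2C(=O)Nc2ccccc2Cl)cc1` in an ADME assay on Vero cells (Chlorocebus sabaeus) for cytotoxicity, read by XTT assay, with a stated time of 72 h (on this read-out lower numbers stand for higher toxicity in this test and higher numbers for lower toxicity in this test), gives > 100000 nM, which is a limit of the assay.
Compound 2 `CC1=C(C(=O)Nc2ccccn2)C(c2cccs2)NC(=O)N1` in this assay gives > 100000 nM, which is likewise a limit of the assay.

Within the data shown here, compound 2 thus stands at the assay limit, as does the one other value shown (the limit of > 100000 nM in this assay, at which 2 of the 2 values shown sit); no number was reached for either, so no step between measured compounds can be counted. Compound 3 `CC1=C(C(=O)Nc2ccccc2Cl)C(c2cccs2)NC(=O)N1` has not yet been measured. Its change from compound 2 is 2-chlorophenyl in place of pyridin-2-yl on an amide-type nitrogen. The same 2-chlorophenyl group on the amide nitrogen is already present in compound 1, whose value sits at the limit. In this assay no shift beyond the usual scatter is expected. The step is estimated as a step that the limit leaves unreadable from compound 2 to compound 3, meaning no change worth noting. On that basis compound 3 is expected to give 150000 nM, within a range of 80000 nM to 300000 nM, and most likely to be reported only as a limit.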

Compound 3, half-maximal cytotoxic concentration: > 100000 nM
Compound 3 was reported as a limit (the forecaster's own chance of this, stated with the estimate: 85%); the middle value is on the limit's open side.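

Compound 1, compound 2 and compound 3 all give only a limit in this assay, so no step between them can be read: the limit of > 100000 nM in this assay, at which 3 of the 3 values shown sit.

The compounds shown leave open whether any change at the amide nitrogen or the saturated ring carbon would give a measurable value in this assay at all.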